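A few compounds are considered here, and "the series" means these few. Any claim that something is new, unique, unknown or untested is made for them only; others in the source may bear on it.

Measured so far:
- compound 1 `COc1cc2nccc(Oc3ccc(Nc4nn(C)cc4C(=O)NCc4ccccc4)cc3)c2cc1C(N)=O`: > 10000 nM (a limit)
- compound 2 `COc1cc2nccc(Oc3ccc(Nc4nn(C)cc4C(=O)NC4CCCCCCC4)cc3)c2cc1C(N)=O`: 3210 nM
- compound 3 `COc1cc2nccc(Oc3ccc(Nc4nn(C)cc4C(=O)NCC4CCCCC4)cc3)c2cc1C(N)=O`: > 10000 nM (a limit)

Among the measured compounds shown here, in a functional assay on BaF3 cells (Mus musculus) for antiproliferative activity, read by CCK-8 assay and cell counting, with a stated time of 76 h (on this read-out higher numbers stand for weaker inhibition and lower numbers for stronger inhibition), compound 2 gives 3210 nM, the only actual number in the set. The other two results sit at the limit of > 10000 nM in this assay, at which 2 of the 3 values shown sit.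

Compound 4 `COc1cc2nccc(Oc3ccc(Nc4nn(C)cc4C(=O)NOCc4ccccc4)cc3)c2cc1C(N)=O` is the next case, with benzyloxy in place of cyclooctyl on an amide-type nitrogen.

For the measured compounds named here, two measured steps bear on this change, as both start from or end at the cyclooctyl amide. The first is an at least 3.1-fold lower number from compound 1 to compound 2 (0.49 log units; beyond the scatter), where cyclooctyl replaces benzyl. The second is an at least 3.1-fold higher number from compound 2 to compound 3 (0.49 log units; beyond the scatter), where cyclohexylmethyl replaces cyclooctyl. The step that the two limits leave unreadable from compound 1 to compound 3 adds nothing on size. In these three compounds, only cyclooctyl gives a number below the limit, and neither compound 1 nor compound 3 goes against that. The benzyloxy group of compound 4 is closest in name to the benzyl group of compound 1, so a move to a higher number, meaning weaker inhibition, is expected in this assay. The expected change is a 2.2-fold higher number from compound 2 to compound 4 (0.34 log units; beyond the scatter). Going by the values given here, that size rests on only two bounded steps, and a result reported only as a limit is also expected to be quite possible.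

For compound 4 the estimated value is 7000 nM, with an expected range of 2000 nM to 20000 nM.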

Compound 4, half-maximal inhibitory concentration: > 10000 nM
Compound 4: only a limit was reported; the forecaster's own chance of this, stated with the estimate: 50%; middle value at least 1.4-fold (0.15 log units) away from the limit.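

In this assay compound 4 gives > 10000 nM, a limit of the assay and not a number. Benzyloxy in place of cyclooctyl on the amide-type nitrogen, where both groups have 8 heavy atoms, gives an at least 3.1-fold higher number from compound 2 to compound 4 (0.49 log units; beyond the scatter), so matching the heavy-atom count while bringing in a six-membered aromatic ring and a hydrogen-bond acceptor does not keep the number seen with cyclooctyl; the steps from compound 1 and compound 3 to compound 4 cannot be read, as both ends are limits. Cyclooctyl now stands as the only one of four groups on this nitrogen with a number, and no compound shown goes against that: the limit of > 10000 nM in this assay, at which 3 of the 4 values shown sit.

Benzyl, cyclohexylmethyl and benzyloxy cannot be ranked against one another, since all three results are limits. Also open, from the compounds shown here alone, is whether the eight-membered ring itself matters or only a saturated ring bound directly to the amide-type nitrogen, which a cyclohexyl or cycloheptyl group at the same place would separate.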